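The source may hold more compounds than are shown below. What is called first, only, known or untested is meant among the compounds shown, and "the series" means these compounds.

In a functional assay on HCT-116 cells (Homo sapiens) for antiproliferative activity, read by CellTiter-Glo, with a stated time of 72 h (a higher number here means a weaker inhibitor, a lower number a stronger inhibitor), two related compounds have been measured so far. Compound 1 (`O=C(NO)c1cccc(/C=C/c2ccnc(-c3ccccc3O)c2)c1`) gives 3360 nM, and compound 2 (`COc1ccccc1-c1cc(/C=C/c2ccc(C(=O)NO)cc2)ccn1`) gives 8440 nM, the higher number of the two, with a gap beyond the usual scatter. The account now moves from compound 2 to compound 3 (`O=C(NO)c1ccc(/C=C/c2ccnc(-c3cccc(CO)c3)c2)cc1`), which has not yet been measured. The change is 3-(hydroxymethyl)phenyl in place of 2-methoxyphenyl on an aromatic carbon, next to the ring nitrogen. Among the measured compounds shown here, the two measured compounds differ in more than one place, so no single step in this assay can serve as a guide. A modest move to a lower number is still expected, not far beyond the scatter, with compound 1 at 3360 nM as the only other reference. The expected step is a 2.1-fold lower number from compound 2 to compound 3 (0.32 log units; beyond the scatter). For compound 3 the estimated value is 4000 nM, with an expected range of 1200 nM to 12000 nM.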

Compound 3, half-maximal inhibitory concentration: 1700 nM
The estimate for compound 3 lay 2.4-fold (0.37 log units) above the measured number; the measured number falls inside the stated range.
By their numbers in this assay, from the lowest: compounds 3 and 1 (each within the scatter of the next); then compound 2.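

In this assay, among the compounds shown here, putting 3-(hydroxymethyl)phenyl in place of 2-methoxyphenyl gives a 5.0-fold lower number from compound 2 to compound 3 (0.70 log units; beyond the scatter), the first step at this position that can be read as a change in one place. It shows that the number responds to the aromatic group on this carbon, next to the ring nitrogen, even when the entering and leaving groups have the same atoms and the same heavy-atom count. No other measurement bears on why the step occurs.

The change alters the place of the oxygen-bearing substituent and adds a hydrogen-bond donor in one move, and these compounds do not separate the two. They also leave open how an amine or a carboxylic acid would compare with the hydroxymethyl group on the same phenyl ring.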